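A few compounds are considered here, and "the series" means these few. Any claim that something is new, unique, unknown or untested is made for them only; others in the source may bear on it.

Three compounds have been measured in an ADME assay on HCT-116 cells (Homo sapiens) for cytotoxicity, read by CellTiter-Glo, with a stated time of 72 h; on this read-out higher numbers stand for weaker inhibition and lower numbers for stronger inhibition:

Compound 1 `Cc1noc(C)c1S(=O)(=O)N1CCC(N2CCC(C)CC2)CC1`: in this assay compound 1 gives > 10000 nM, a limit of the assay rather than a number.
Compound 2 `Cc1cc(C)c(S(=O)(=O)N2CCC(N3CCC(O)CC3)CC2)c(C)c1`: in this assay compound 2 gives > 5000 nM, again a limit and not a number.
Compound 3 `Cc1c(C)c(S(=O)(=O)N2CCC(N3CCC(C)CC3)CC2)c(C)c2c1OC(C)(C)C2`: in this assay compound 3 gives > 10000 nM, also a limit.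

Compound 1 stands at the limit of > 10000 nM in this assay, at which 2 of the 3 values shown sit. Compound 3 sits at that same limit. Compound 2 sits at the limit of > 5000 nM in this assay, at which 1 of the 3 values shown sits. None of the three therefore carries a number in this assay, and nothing among them sets one apart from another. Among the measured compounds shown here, no step between measured compounds is available to size a structural change.

Compound 4 `Cc1ccc(S(=O)(=O)N2CCC(N3CCC(C)CC3)CC2)cc1C` has not yet been measured. It differs from compound 1 at one place: 3,4-dimethylphenyl in place of 3,5-dimethyl-1,2-oxazol-4-yl on a sulfonyl sulfur.

With compound 1 resting at a limit, the account can only say what is expected. The step is estimated as a step that the limit leaves unreadable from compound 1 to compound 4, which is expected to lie within the scatter and to bring no change of direction. Compound 4 is therefore expected to give 15000 nM in this assay, within a range from 5000 nM to 50000 nM, with a limit rather than a number the most likely outcome.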

Compound 4, half-maximal inhibitory concentration: > 5000 nM
Compound 4 ended at the assay's limit; the forecaster's own chance of this, stated with the estimate: 85%; the middle value lies beyond the limit too.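

In this assay compound 4 gives > 5000 nM, a limit of the assay and not a number. Compound 1 also rests at a limit, so the step between compound 1 and compound 4 cannot be read. The compounds shown leave open whether swapping 3,5-dimethyl-1,2-oxazol-4-yl for 3,4-dimethylphenyl changes cytotoxicity at all.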